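A few compounds are considered here, and "the series" means these few. Any claim that something is new, unique, unknown or untested is made for them only; others in the source may bear on it.

Measured so far:
- compound 1, `CNC(=O)c1ccc(Sc2cccc(NC(=S)Nc3ccc(F)c(Cl)c3)c2)nc1`: > 100000 nM
- compound 2, `CNC(=O)c1ccc(Sc2cccc(NC(=S)Nc3ccc(Br)c(C(F)(F)F)c3)c2)nc1`: > 100000 nM

Both compounds carry the same thiourea-linked framework and differ only in the two small groups on the outer aromatic ring. In a functional assay on B16-BL6 cells (Mus musculus) for cytotoxicity, read by MTT assay, with a stated time of 48 h (on this read-out lower numbers stand for stronger inhibition and higher numbers for weaker inhibition), compound 1 shows no measured number, only a limit of the assay, > 100000 nM. In this assay compound 2 likewise shows only a limit, > 100000 nM, and not a number. Among the measured compounds shown here, compound 2 therefore stands at the top edge of what this assay can report, the same place as the only other value in hand (the limit of > 100000 nM in this assay, at which 2 of the 2 values shown sit).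

The next compound, compound 3, `CNC(=O)c1ccc(Sc2cccc(NC(=S)Nc3ccc(Cl)c(C(F)(F)F)c3)c2)nc1`, is built from compound 2 by a single small swap: chloro in place of bromo on an aromatic carbon. For the measured compounds named here, no step between two measured compounds is available to calibrate such a swap, and both known values are limits rather than numbers. In this assay the expected change is none beyond the usual scatter. The expected step of a number no higher from compound 2 to compound 3 (the limit leaves the size open) is essentially flat. Compound 3 is estimated to give 100000 nM, within 30000 nM to 300000 nM, most likely again as a limit.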

Compound 3, half-maximal inhibitory concentration: 19800 nM
Estimate against measurement, compound 3: 5.1-fold (0.70 log units) above, outside the stated range (below it).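

In this assay, chloro in place of bromo on an aromatic carbon, ortho to a trifluoromethyl group and para to a large group, gives an at least 5.0-fold lower number from compound 2 to compound 3 (0.70 log units; beyond the scatter). Among the compounds shown here, this shows what the earlier compounds could not: a swap of a single atom at this position can move the read-out off the top edge of the assay. Compound 3 gives a real number, 19800 nM. The other two compounds shown give only limits. The full size of the step remains unknown because compound 2 gives a limit and not a number: the limit of > 100000 nM in this assay, at which 2 of the 3 values shown sit.

The compounds shown leave open whether a plain hydrogen, a methyl group, a methoxy group or an amine on this same carbon would give a lower number than chloro, a similar one or a higher one. For the compounds shown here, they also leave open why chloro and bromo differ here, and whether the same swap would have a similar result with something other than trifluoromethyl on the ring, as no property of either group is measured and only this one pair can be read.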